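Replacing Methoxycarbonyl by Ethylamino: an Expected Binding Value

This account rests on a few compounds, and the source may have more. Where it says the series, first, only, none or still open, it means among the compounds named here.

Compound 1 `CN1CCC[C@H]1COc1cccnc1` gives 0.15 nM in an assay on membranes from brain for displacement of a labelled ligand from Neuronal acetylcholine receptor; alpha4/beta2 (Rattus norvegicus); on this read-out lower numbers stand for stronger inhibition and higher numbers for weaker inhibition. For the measured compounds named here, compound 2 `COC(=O)c1cncc(OC[C@@H]2CCCN2C)c1` gives 1.45 nM, the higher of the two numbers measured so far, and the one measured step, a 9.7-fold higher number from compound 1 to compound 2 (0.99 log units; beyond the scatter), shows that placing methoxycarbonyl on the shared core weakened binding clearly. Compound 3 `CCNc1cncc(OC[C@@H]2CCCN2C)c1` differs from compound 2 by ethylamino in place of methoxycarbonyl on an aromatic carbon. Going by the values given here, no measured step tells what ethylamino does at this place, so the direction is uncertain. For compound 3 the number is therefore expected to lie between the two measured values, as a 2.4-fold lower number from compound 2 to compound 3 (0.38 log units; beyond the scatter), with an estimate of 0.6 nM and a range from 0.12 nM to 3 nM.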

Compound 3, inhibition constant: 3.7 nM
The estimate for compound 3 lay 6.2-fold (0.79 log units) below the measured number, outside the stated range (above it).
By their numbers in this assay, from the lowest: compound 1; then compound 2; then compound 3.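

In this assay, ethylamino in place of methoxycarbonyl gives a 2.6-fold higher number from compound 2 to compound 3 (0.41 log units; beyond the scatter) at this position, so of the two groups, ethylamino is the less favourable here. Ethylamino in place of hydrogen gives a 25-fold higher number from compound 1 to compound 3 (1.39 log units; beyond the scatter) on the shared core, so both groups tried at this aromatic carbon weaken binding, ethylamino by more. Nothing available explains why these two groups differ. Still open, as far as these compounds go, is whether a plain amine, a carboxylic acid or a longer chain at this position would weaken binding less, or whether any group here could match hydrogen.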